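The source may report more compounds than this note shows. Statements on the series, on what has been measured and on what is new or still open speak of the compounds shown alone.

Compound 1, `CNc1c(C#N)c2c(N)ncnc2n1COCCOC`: > 100000 nM
Compound 2, `NC(=O)c1c(N)n(COCc2ccccc2)c2ncnc(N)c12`: > 100000 nM

Compound 1 `CNc1c(C#N)c2c(N)ncnc2n1COCCOC` was tested in a functional assay on KB cells (Homo sapiens) for inhibition; on this read-out higher numbers stand for weaker inhibition and lower numbers for stronger inhibition. In this assay compound 1 gives > 100000 nM, which is a limit of the assay and not a number. Compound 2 `NC(=O)c1c(N)n(COCc2ccccc2)c2ncnc(N)c12` was tested in the same assay. In this assay compound 2 gives > 100000 nM, again a limit rather than a measured number. Within the data shown here, both values sit at the limit of > 100000 nM in this assay, at which 2 of the 2 values shown sit, so no step between measured compounds can be stated, and compound 1 stands at that limit without a number to place it more closely.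

Compound 3 `COCCOCn1c(N(C)C)c(C#N)c2c(N)ncnc21` has not yet been measured in this assay. It differs from compound 1 by methyl in place of hydrogen on a nitrogen on an aromatic ring. Among the measured compounds shown here, nothing among the measured values shows how this change acts in this assay. Compound 1 reaches only a limit, and the step of a number no higher from compound 1 to compound 3 (the limit leaves the size open) is expected to be none beyond the scatter. For compound 3 the estimate in this assay is 100000 nM, with a range from 30000 nM to 300000 nM, and the result is expected most likely to be reported again only as a limit.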

Compound 3, half-maximal inhibitory concentration: > 100000 nM
Compound 3 was reported as a limit; the forecaster's own chance of this, stated with the estimate: 85%; the middle value sits exactly at the limit.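

In this assay compound 3 gives > 100000 nM, which is a limit of the assay and not a number, so no step from compound 1 to compound 3 can be read: the limit of > 100000 nM in this assay, at which 3 of the 3 values shown sit.

The compounds shown leave open whether methyl in place of hydrogen on a nitrogen on an aromatic ring changes inhibition at all.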